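Ester Changes on a Shared Core

The source may hold more compounds than are shown below. What is called first, only, known or untested is meant among the compounds shown, and "the series" means these compounds.

Three compounds share one core and differ only in the ester group. Compound 1 `CC/C=C\C[C@H]1C(=O)C=C[C@H]1CC(=O)OCC` is the ethyl ester; compound 2 `CC/C=C\C[C@H]1C(=O)C=C[C@H]1CC(=O)Oc1ccccc1` carries a phenyl ester and compound 3 `CC/C=C\C[C@H]1C(=O)C=C[C@H]1CC(=O)OCCOCCO` a chain that ends in a hydroxyl. In a functional assay on RAW264.7 cells (Mus musculus) for inhibition, read by ELISA, with a stated time of 24 h (on this read-out higher numbers stand for an effect only at larger amounts of compound and lower numbers for an effect already at smaller amounts), compound 1 gives 20000 nM, compound 2 gives 33000 nM and compound 3 gives 36000 nM. Compound 1 has the lowest of these three numbers, but the step of a 1.7-fold higher number from compound 1 to compound 2 (0.22 log units; within the scatter) and the step of a 1.8-fold higher number from compound 1 to compound 3 (0.26 log units; within the scatter) both stay within the scatter, as does a 1.1-fold higher number from compound 2 to compound 3 (0.04 log units; within the scatter), so the three compounds cannot be told apart on this read-out.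

Compound 4 `CC/C=C\C[C@H]1C(=O)C=C[C@H]1CC(=O)OCCOC` has not yet been measured. It differs from compound 1 by methoxy in place of hydrogen on a saturated chain carbon, two bonds along the chain from an oxygen next to a carbonyl group. The closest measured comparison is the step of a 1.8-fold higher number from compound 1 to compound 3 (0.26 log units; within the scatter), where a larger group entered at the same place without moving the number beyond the scatter; the step of a 1.7-fold higher number from compound 1 to compound 2 (0.22 log units; within the scatter) points the same way. Going by the values given here, nothing measured so far suggests that a change to the ester shifts this assay, so no step beyond the scatter is expected here. Compound 4 is therefore estimated at 25000 nM, with a range of 10000 nM to 60000 nM, which corresponds to an expected step of a 1.3-fold higher number from compound 1 to compound 4 (0.10 log units; within the scatter).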

Compound 4, half-maximal effective concentration: 27000 nM
Beside the measured number, compound 4's estimate is 1.1-fold (0.03 log units) below it; the range from low to high includes it.
By their numbers in this assay, from the lowest: compounds 1, 4, 2 and 3 (each within the scatter of the next).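

Methoxy in place of hydrogen on this saturated chain carbon gives, in this assay, a 1.4-fold higher number from compound 1 to compound 4 (0.13 log units; within the scatter) and so extends the ester chain with a group that has no hydrogen-bond donor while leaving compound 4 indistinguishable from compound 1. Compound 3 differs from compound 4 by a hydroxymethyl in place of hydrogen on a saturated chain carbon bound to an oxygen on a saturated carbon, and the result is a 1.3-fold lower number from compound 3 to compound 4 (0.12 log units; within the scatter) so having a hydroxyl at the end of the chain or a methoxy there makes no readable difference. The step of a 1.2-fold lower number from compound 2 to compound 4 (0.09 log units; within the scatter) shows the same for 2-methoxyethyl in place of phenyl on the oxygen next to the carbonyl group, which leaves all four esters inseparable on this read-out.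

On these data alone, it remains open whether an amine at the end of the chain, a carboxylic acid in place of the ester or a much longer chain would move the number beyond the scatter. No measurement shown accounts for how closely these numbers sit together.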